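This account rests on a few compounds, and the source may have more. Where it says the series, first, only, none or still open, it means among the compounds named here.

Compound 1 `CNC(=O)c1cc(Oc2ccc(NC(=O)c3cc(-c4ccc(C(F)(F)F)cc4)ncn3)cc2F)ccn1`: > 100000 nM
Compound 2 `CNC(=O)c1cc(Oc2ccc(NC(=O)c3cc(-c4ccc(Cl)cc4)ncn3)cc2)ccn1`: > 100000 nM
Compound 3 `CNC(=O)c1cc(Oc2ccc(NC(=O)c3cc(-c4ccccc4)ncn3)cc2)ccn1`: 27100 nM

All three were tested in a functional assay on A549 cells (Homo sapiens) for cytotoxicity, read by MTT assay, with a stated time of 72 h; a higher number here means a weaker inhibitor, a lower number a stronger inhibitor. Compound 1 stands at the limit of > 100000 nM in this assay, at which 2 of the 3 values shown sit, and this is a limit of the assay, not a number. The entry for compound 2 is a limit too. Only compound 3, at 27100 nM, has a true number.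

Compound 4 `CNC(=O)c1cc(Oc2ccc(NC(=O)c3cc(-c4ccc(OC)cc4)ncn3)cc2F)ccn1` has not yet been measured. It differs from compound 1 as follows: methoxy in place of trifluoromethyl on an aromatic carbon. Within the data shown here, one measured step touches the same place on the molecule: an at least 3.6-fold lower number from compound 2 to compound 3 (0.56 log units; beyond the scatter). Among the measured compounds shown here, that step removes a group rather than exchanging one, and no methoxy compound has a measured value, so it is only a weak guide. Still, it shows that a change at this place can bring a number out from the limit, so a modest move to a lower number is expected. The expected step is an at least 2.2-fold lower number from compound 1 to compound 4 (0.34 log units; beyond the scatter). For compound 4 the estimated value is 45000 nM, with an expected range of 13000 nM to 100000 nM.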

Compound 4, half-maximal inhibitory concentration: 34500 nM
For compound 4 the middle estimate is 1.3-fold (0.12 log units) above the measured one, and the stated range covers the measured number.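

The earlier step at this place took a group away, while this one exchanges one group for another on the same aromatic carbon. In this assay, methoxy in place of trifluoromethyl gives an at least 2.8-fold lower number from compound 1 to compound 4 (0.46 log units; beyond the scatter), so a replacement, and not only a removal, can bring a compound off the limit. Compound 1 stands at a limit and not at a number, so the true size of this step stays unknown: the limit of > 100000 nM in this assay, at which 2 of the 4 values shown sit.

The compounds shown leave open how an amine, a carboxylic acid or a longer chain such as ethoxy would read at this place. From the compounds shown here alone, compound 3 and compound 4 differ in more than one place, so whether methoxy improves on plain hydrogen here also stays open.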